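Swapping the Group on the Carbonyl Carbon

The compounds below may be only part of what the source reports. "The series", "measured", "known", "first", "only" and "open" are said of these compounds alone.

Measured so far:
compound 1 `Cc1ccccc1C(=O)n1c(-c2cn(-c3ccccc3)nc2-c2ccc(F)cc2)nc2ccccc21` gives 189000 nM in an ADME assay on HEK-293T cells (Homo sapiens) for cytotoxicity, read by MTT assay, with a stated time of 24 h; a higher number here means that more compound is tolerated, a lower number that less compound is tolerated
compound 2 `O=C(c1cccnc1)n1c(-c2cn(-c3ccccc3)nc2-c2ccc(F)cc2)nc2ccccc21` gives 216000 nM in this assay
compound 3 `O=C(c1ccc(Cl)cc1)n1c(-c2cn(-c3ccccc3)nc2-c2ccc(F)cc2)nc2ccccc21` gives 179000 nM in this assay

The three compounds share one core and differ only in the group attached to the carbonyl carbon. Compound 3 has the lowest of the three numbers in this assay, but this stands on nothing firm: the step of a 1.1-fold lower number from compound 1 to compound 3 (0.02 log units; within the scatter) and the step of a 1.2-fold lower number from compound 2 to compound 3 (0.08 log units; within the scatter) are both within the scatter, as is the step of a 1.1-fold higher number from compound 1 to compound 2 (0.06 log units; within the scatter). The three values are therefore indistinguishable.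

Compound 4 `Cc1cccc(C(=O)n2c(-c3cn(-c4ccccc4)nc3-c3ccc(F)cc3)nc3ccccc32)c1` has not yet been measured in this assay. It differs from compound 3 as follows: 3-methylphenyl in place of 4-chlorophenyl on a carbonyl carbon. The measured steps that bear on this are the two that also exchange the group on the carbonyl carbon of compound 3, namely a 1.1-fold lower number from compound 1 to compound 3 (0.02 log units; within the scatter) and a 1.2-fold lower number from compound 2 to compound 3 (0.08 log units; within the scatter), and each of them is within the scatter. Within the data shown here, nothing among the measured steps suggests that a further exchange at the same place would move the number beyond the scatter, so the step expected from compound 3 to compound 4 is a 1.1-fold higher number from compound 3 to compound 4 (0.03 log units; within the scatter), that is, none of note. Compound 4 is accordingly estimated to give about 190000 nM in this assay, with a range from 120000 nM to 300000 nM.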

Compound 4, half-maximal cytotoxic concentration: 148000 nM
Compound 4: middle estimate off by 1.3-fold (0.11 log units), on the high side, within the range that was stated.
By their numbers in this assay, from the lowest: compounds 4, 3, 1 and 2 (each within the scatter of the next).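

In this assay, 3-methylphenyl in place of 4-chlorophenyl on the carbonyl carbon gives a 1.2-fold lower number from compound 3 to compound 4 (0.08 log units; within the scatter) and so adds a fourth group without separating it from the others. The same holds against the remaining two groups, with a 1.3-fold lower number from compound 1 to compound 4 (0.11 log units; within the scatter) for the exchange from 2-methylphenyl and a 1.5-fold lower number from compound 2 to compound 4 (0.16 log units; within the scatter) for the exchange from pyridin-3-yl, the largest step among the four compounds and still not a distinguishable one. Across these four compounds, then, the position takes two methylphenyl groups, a 4-chlorophenyl group and a pyridin-3-yl group with no difference that can be read, so the methyl group's place on the phenyl ring also shows no readable effect between compound 1 and compound 4, and no evidence is at hand that bears on this result.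

What the compounds shown leave open is whether a group of another kind on the carbonyl carbon, such as an amine, a carboxylic acid or a longer alkyl chain, would move the number beyond the scatter. They also leave open whether any change elsewhere on the shared core would do so, as all four compounds differ only at this one place.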